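Compound 3 to compound 4: a shorter selenium side group

The compounds below may be only part of what the source reports. "The series", "measured", "known", "first", "only" and "open" are said of these compounds alone.

In a functional assay on MDA-MB-231 cells (Homo sapiens) for inhibition, read by MTT assay, with a stated time of 48 h (on this read-out higher numbers stand for weaker inhibition and lower numbers for stronger inhibition), compound 3 (`COc1ccc(N(C)c2nc(C)nc3ccccc23)cc1OCC[Se]C#N`) gives 13 nM. Compound 2 (`COc1ccc(N(C)c2nc(C)nc3ccccc23)cc1[Se]C`) gives 10 nM, and compound 1 (`COc1ccc(N(C)c2nc(C)nc3ccccc23)cc1C(=O)OCCC[Se]C#N`) gives 1180 nM. Compound 3 thus lies within the scatter of compound 2 and far from compound 1.

Compound 4 (`COc1ccc(N(C)c2nc(C)nc3ccccc23)cc1[Se]C#N`) carries a group of 3 heavy atoms (1 carbon, 1 nitrogen, 1 selenium; no ring) in place of a group of 6 heavy atoms (3 carbon, 1 nitrogen, 1 oxygen, 1 selenium; no ring), on an aromatic carbon. Two large steps bear on this, a 120-fold lower number from compound 1 to compound 2 (2.07 log units; beyond the scatter) and a 91-fold lower number from compound 1 to compound 3 (1.96 log units; beyond the scatter), and both leave the ester side group. The third, a 1.3-fold higher number from compound 2 to compound 3 (0.11 log units; within the scatter), stays within the scatter. Going by the values given here, no measured compound has the entering group itself, so the evidence is indirect. The expected change is none beyond the scatter, with an estimated 1.1-fold lower number from compound 3 to compound 4 (0.03 log units; within the scatter). For compound 4 the estimate is 12 nM, with an expected range of 3 nM to 50 nM.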

Compound 4, half-maximal inhibitory concentration: 52 nM
Compound 4: middle estimate off by 4.3-fold (0.64 log units), on the low side; the whole stated range lies below it.
By their numbers in this assay, from the lowest: compounds 2 and 3 (each within the scatter of the next); then compound 4; then compound 1.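

In this assay, the selenium side group on this aromatic carbon turns out not to be freely exchangeable: a 4.0-fold higher number from compound 3 to compound 4 (0.60 log units; beyond the scatter) and a 5.2-fold higher number from compound 2 to compound 4 (0.72 log units; beyond the scatter) both lie beyond the scatter, although compound 2 and compound 3 had stood level. Cyano in place of methyl on a selenium therefore counts here, yet a 23-fold lower number from compound 1 to compound 4 (1.36 log units; beyond the scatter) keeps compound 4 well clear of the ester side group. No measurement bears on what lies behind these steps.

Going by these compounds, whether a longer chain on the selenium, or an amine in place of the cyano, would sit with compound 2 or with compound 4 stays open.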